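Methyl in place of methoxy: expectation for compound 3

The compounds below may be only part of what the source reports. "The series", "measured", "known", "first", "only" and "open" are said of these compounds alone.

For the measured compounds named here, in a functional assay on HL-60 cells (Homo sapiens) for cytotoxicity, read by WST assay, with a stated time of 48 h (on this read-out higher numbers stand for an effect only at larger amounts of compound and lower numbers for an effect already at smaller amounts), compound 2 (`COc1ccc(C[C@H]2COC(=O)[C@@H]2Cc2ccc(Cl)c(Cl)c2)cc1`) gives 37000 nM and compound 1 (`Cc1cccc(C[C@H]2COC(=O)[C@@H]2Cc2ccc(Cl)c(Cl)c2)c1`) gives 22000 nM as the only two values so far. Going by the values given here, these two lie within the scatter of each other, so compound 2 stands level with its sole neighbour.

Compound 3 (`Cc1ccc(C[C@H]2COC(=O)[C@@H]2Cc2ccc(Cl)c(Cl)c2)cc1`) keeps the shared core and has methyl in place of methoxy on an aromatic carbon, para to a large group, with methyl in place of methoxy on an aromatic carbon as the count of the change, which also reads 4-methoxyphenyl to 4-methylphenyl.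

The step of a 1.7-fold higher number from compound 1 to compound 2 (0.23 log units; within the scatter) is the only measured one that bears on this change. Among the compounds with values here, compound 1 also carries a methyl on its aromatic ring, but that step alters the place of the group as well as its kind, and no measured pair compares methoxy with methyl at one place. On this thin evidence, no step beyond the scatter is expected in this assay for this change. The expected change is a 1.3-fold lower number from compound 2 to compound 3 (0.12 log units; within the scatter) and stays within the scatter. For compound 3 the estimate is 28000 nM with an expected range from 14000 nM to 55000 nM in this read-out.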

Compound 3, half-maximal effective concentration: 19000 nM
The estimate for compound 3 lay 1.5-fold (0.17 log units) above the measured number, and the stated range covers the measured number.
By their numbers in this assay, from the lowest: compounds 3, 1 and 2 (each within the scatter of the next).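

In this assay the methoxy and methyl groups can now be compared directly at one place, on an aromatic carbon, para to a large group: the change from 4-methoxyphenyl to 4-methylphenyl gives a 1.9-fold lower number from compound 2 to compound 3 (0.29 log units; within the scatter) and so does not separate the two groups at this position. The place of the methyl can also now be read apart from its kind, since 4-methylphenyl in place of 3-methylphenyl gives a 1.2-fold lower number from compound 1 to compound 3 (0.06 log units; within the scatter) and leaves these two compounds level in this read-out. Nothing available accounts for either step, and with all three compounds within the scatter of one another there is no difference here to explain.

As far as these compounds go, the aryl groups compared so far carry only methyl or methoxy, so it remains open whether an amine, a carboxylic acid or a longer chain such as propyl at this place would give a step beyond the scatter. Also open, from the compounds shown here alone, is whether methoxy and methyl would stand as level in the position the methyl occupies in compound 1, and whether the dichlorophenyl side of the shared core would tolerate a change as evenly.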